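Compound 1 to compound 4: phenyl for 3,5-dimethylphenyl

A few compounds are considered here, and "the series" means these few. Any claim that something is new, unique, unknown or untested is made for them only; others in the source may bear on it.

Three compounds have been measured in a functional assay on CAL-27 cells (Homo sapiens) for cytotoxicity, read by MTT assay, with a stated time of 72 h; a lower number here means a stronger inhibitor, a higher number a weaker inhibitor:

- compound 1 `Cc1cc(C)cc(C(=O)N(CCCCCC(=O)Nc2ccccc2N)CC(=O)NC2CCCCC2)c1`: 17500 nM
- compound 2 `CN(C)c1ccc(C(=O)N(CC(=O)NCc2ccccc2)Cc2ccc(C(=O)Nc3cc(-c4ccccc4)ccc3N)cc2)cc1`: 11100 nM
- compound 3 `Cc1cc(C)cc(C(=O)N(CCCCCC(=O)Nc2ccccc2N)CC(=O)NCc2ccccc2)c1`: 13700 nM

Compound 1 lies within the scatter of both other compounds, so these values do not rank it against them. Compound 4 `Nc1ccccc1NC(=O)CCCCCN(CC(=O)NC1CCCCC1)C(=O)c1ccccc1` differs from it in a single place: phenyl in place of 3,5-dimethylphenyl on a carbonyl carbon. In words, it carries phenyl in place of 3,5-dimethylphenyl on a carbonyl carbon.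

Going by the values given here, no measured step tests this change directly. The closest evidence is a 1.3-fold lower number from compound 1 to compound 3 (0.11 log units; within the scatter), which lies within the scatter but concerns an amide-type nitrogen and not this carbonyl carbon. Differing from compound 1 in more than one place, compound 2 at 11100 nM also stays within the scatter of compound 1. On this limited evidence, no step beyond the scatter is expected in this assay, and no direction can be assigned with confidence.

The expected change is a 1.0-fold higher number from compound 1 to compound 4 (0.01 log units; within the scatter).

For compound 4, the estimated value is 18000 nM, with an expected range of 9000 nM to 36000 nM.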

Compound 4, half-maximal inhibitory concentration: 30900 nM
Beside the measured number, compound 4's estimate is 1.7-fold (0.23 log units) below it, and the stated range covers the measured number.
By their numbers in this assay, from the lowest: compounds 2, 3, 1 and 4 (each within the scatter of the next, the first and the last beyond it).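

In this assay, the carbonyl carbon position gets its first direct test, and phenyl in place of 3,5-dimethylphenyl gives a 1.8-fold higher number from compound 1 to compound 4 (0.25 log units; within the scatter) while the rest of compound 1 stays the same. The earlier compounds shown here varied only the group on the amide-type nitrogen in a single-place step, so this result extends the picture to the other end of the molecule: on this evidence, compound 1 and compound 4 cannot be ranked, and the 3,5-dimethylphenyl and phenyl groups are not told apart at this position. No measurement available here offers an explanation for the size of this step.

On these data alone, what remains open is whether a methoxy group, a chlorine atom or a carboxylic acid on this ring would give a step beyond the scatter in this assay. As far as these compounds go, it is also open whether phenyl in place of 3,5-dimethylphenyl would give a similar step when benzyl replaces cyclohexyl on the amide-type nitrogen, as in compound 3 at 13700 nM.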